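Chloro Substitution on the Core of Compound 2

The source may hold more compounds than are shown below. What is called first, only, known or untested is meant among the compounds shown, and "the series" means these compounds.

Compound 2 `Cc1nnc(SCc2cc(=O)c3ccccc3o2)s1` is measured in a functional assay on HEp-2 cells (Homo sapiens) for cytotoxicity, read by MTT assay, with a stated time of 72 h (on this read-out lower numbers stand for stronger inhibition and higher numbers for weaker inhibition), and gives only a limit, > 25000 nM. Compound 3 `Nc1nnc(SCc2cc(=O)c3ccccc3o2)s1`, which differs from it by amino in place of methyl on an aromatic carbon, also gives a limit, > 25000 nM. The step that the two limits leave unreadable from compound 2 to compound 3 cannot be read because of the limit of > 25000 nM in this assay, at which 2 of the 3 values shown sit. Compound 1 `Cc1nnc(SCc2coc3ccc(Cl)cc3c2=O)s1`, built on a different core, gives 4200 nM in this assay. Compound 4 `Cc1nnc(SCc2cc(=O)c3cc(Cl)ccc3o2)s1` is not yet measured; it differs from compound 2 by chloro in place of hydrogen on an aromatic carbon. Within the data shown here, no measured step bears directly on this change; compound 1 carries a chloro group but differs from compound 2 in more than one place, so its value shows only that a chloro-bearing analogue reached a number in this assay. Compound 4 is expected at 15000 nM, between 4000 nM and 60000 nM. The expected step is an at least 1.6-fold lower number from compound 2 to compound 4 (0.22 log units; that floor lies within the scatter).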

Compound 4, half-maximal inhibitory concentration: > 25000 nM
Compound 4: only a limit was reported (the forecaster's own chance of this, stated with the estimate: 45%); middle value at least 1.6-fold (0.22 log units) away from the limit.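

In this assay compound 2 and compound 4 both give only limits, so the step between them cannot be read: the limit of > 25000 nM in this assay, at which 3 of the 4 values shown sit. Going by these compounds, whether chloro in place of hydrogen changes the number on the shared core stays open.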